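The compounds below may be only part of what the source reports. "The series", "measured", "known", "first", "only" and "open" are said of these compounds alone.

Three compounds share one core and differ only in the group carried on the oxygen of the oxime. Compound 3 `CCOC(=O)CO/N=C/c1c(N)ncnc1Oc1ccc(NC(=O)C2(C(=O)Nc3ccc(F)cc3)CC2)cc1F` gives 3.15 in a physicochemical assay for lipophilicity, using the shake flask method; on this read-out higher numbers stand for higher lipophilicity and lower numbers for lower lipophilicity. Among the three numbers this is the second highest: its nearest neighbour is compound 1 `CCO/N=C/c1c(N)ncnc1Oc1ccc(NC(=O)C2(C(=O)Nc3ccc(F)cc3)CC2)cc1F`, which in this assay gives 3.41, a gap within the scatter; its furthest is compound 2 `Nc1ncnc(Oc2ccc(NC(=O)C3(C(=O)Nc4ccc(F)cc4)CC3)cc2F)c1/C=N/OCCO`, which gives 2.37.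

Compound 4 `Nc1ncnc(Oc2ccc(NC(=O)C3(C(=O)Nc4ccc(F)cc4)CC3)cc2F)c1/C=N/OC1CCCCC1` is the next step, which puts (cyclohexyl in place of (ethoxycarbonyl)methyl on an oxygen). The group that leaves carries two hydrogen-bond acceptors and a double bond outside aromatic rings; the group that enters is a ring of carbon only, with no hydrogen-bond acceptors.

Going by the values given here, two measured steps bear on this. The change a number 0.78 log units higher from compound 2 to compound 3 (beyond the scatter) and the change a number 0.26 log units lower from compound 1 to compound 3 (within the scatter) together show that trading hydroxymethyl for ethoxycarbonyl raised the number, while trading methyl for ethoxycarbonyl barely moved it. Removing both acceptors and adding a carbon ring is therefore expected to push the number upward, by a step of a number 1.55 log units higher from compound 3 to compound 4 (beyond the scatter). Compound 4 is expected to reach about 4.7, within a range of 4 to 5.4.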

Compound 4, partition coefficient: 4.69
Compound 4: middle estimate off by 0.01 log units, on the high side, and the stated range covers the measured number.
By their numbers in this assay, from the lowest: compound 2; then compounds 3 and 1 (each within the scatter of the next); then compound 4.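

At this oxygen, cyclohexyl gives the highest number of the four in this assay, standing clear of (ethoxycarbonyl)methyl (a number 1.54 log units higher from compound 3 to compound 4 (beyond the scatter)), of ethyl (a number 1.28 log units higher from compound 1 to compound 4 (beyond the scatter)) and of 2-hydroxyethyl (a number 2.32 log units higher from compound 2 to compound 4 (beyond the scatter)). Going by these compounds alone, no earlier group stood beyond the scatter above compound 1, so this is the first evidence that the number can climb well past the ethyl level at this position. Ethyl also holds only carbon, so a large rise here does not require hydrogen-bond acceptors to leave.

A straight hexyl chain or a smaller cyclopropyl ring on the same oxygen would help show whether the ring or the carbon count goes with this rise. Nothing available here explains why the number moves as it does.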